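Removing one fluorine from the difluoromethyl group

The source may hold more compounds than are shown below. What is called first, only, known or untested is meant among the compounds shown, and "the series" means these compounds.

Compound 1 `Cc1c(C(F)F)nnc2sc(C(=O)NC3CN(c4ncc(C(F)(F)F)cn4)C3)c(N)c12` gives 0.02
Compound 2 `Cc1c(Cl)nnc2sc(C(=O)NC3CN(c4cc(C(F)(F)F)ncc4Cl)C3)c(N)c12` gives 0.019

In an ADME assay on a cell-free system (plasma, Homo sapiens) for protein binding (a lower number here means a smaller unbound share, a higher number a larger unbound share of the compound), compound 1 with 0.02 and compound 2 with 0.019 lie within the scatter of each other. Both compounds sit at a small unbound share. Compound 3 `Cc1c(CF)nnc2sc(C(=O)NC3CN(c4ncc(C(F)(F)F)cn4)C3)c(N)c12` has not yet been measured. It departs from compound 1 by hydrogen in place of fluoro on a saturated chain carbon bound to an aromatic carbon and a fluorine atom which turns difluoromethyl to fluoromethyl. Going by the values given here, no pair of measured compounds shows this change. A small rise is expected, with the estimated 1.3-fold higher number from compound 1 to compound 3 (0.10 log units; within the scatter) staying within the scatter. The estimated value for compound 3 is 0.025 (0.013 to 0.048).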

Compound 3, unbound fraction: 0.042
Beside the measured number, compound 3's estimate is 1.7-fold (0.23 log units) below it; low and high end bracket the measured number.
By their numbers in this assay, from the lowest: compounds 2 and 1 (each within the scatter of the next); then compound 3.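

The change from difluoromethyl to fluoromethyl gives, in this assay, a 2.1-fold higher number from compound 1 to compound 3 (0.32 log units; beyond the scatter). Going by these compounds alone, this is the first readable step at this position, and it shows that losing a single fluorine can shift the unbound share beyond the scatter, though only modestly. Nothing at hand accounts for this rise.

On these data alone, whether a plain methyl group or a hydroxymethyl group at this place would raise the unbound share further remains open. So does whether the same step would hold with the other parts of compound 2 in place.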